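Dropping One Methoxy Group from a Pyrazole Chalcone

This account rests on a few compounds, and the source may have more. Where it says the series, first, only, none or still open, it means among the compounds named here.

Two compounds from the series share a core and differ only in how methoxy groups are arranged on one aromatic ring. Compound 1 `COc1cc(OC)c(C(=O)/C=C/c2cn(-c3ccccc3)nc2-c2ccsc2)c(OC)c1` was tested in a functional assay on HCT-116 cells (Homo sapiens) for inhibition, read by sulforhodamine B assay, with a stated time of 72 h (a higher number here means a weaker inhibitor, a lower number a stronger inhibitor), and compound 1 gives 5200 nM. Compound 2 `COc1ccc(C(=O)/C=C/c2cn(-c3ccccc3)nc2-c2ccsc2)c(OC)c1OC` is its close relative, and in this assay compound 2 gives 5800 nM. Within the data shown here, of the two numbers, the one for compound 2 is the higher, but the two values sit within the scatter of each other, so nothing can be said about which of the pair is the more potent.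

Compound 3 `COc1ccc(C(=O)/C=C/c2cn(-c3ccccc3)nc2-c2ccsc2)c(OC)c1` is the next member, and it changes compound 2 in one place: hydrogen in place of methoxy on an aromatic carbon, a hydrogen in place of methoxy on an aromatic carbon. Among the measured compounds shown here, no step between two measured compounds mirrors this change, so the size of its effect cannot be read from the data; the one comparison available, between compound 1 and compound 2, shows only that rearranging methoxy groups on this ring left the number essentially unchanged. From this, compound 3 is expected to stay close to compound 2, with a step of a 1.1-fold higher number from compound 2 to compound 3 (0.05 log units; within the scatter) in this assay that would not exceed the scatter by much. The estimate for compound 3 is therefore 6500 nM, within a range from 2500 nM to 17000 nM.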

Compound 3, half-maximal inhibitory concentration: 2200 nM
Estimate against measurement, compound 3: 3.0-fold (0.47 log units) above, and the stated range ends above it.
By their numbers in this assay, from the lowest: compound 3; then compounds 1 and 2 (each within the scatter of the next).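

Replacing the methoxy that sits ortho to two methoxy groups and meta to a large group with hydrogen gives, in this assay, a 2.6-fold lower number from compound 2 to compound 3 (0.42 log units; beyond the scatter), a modest change but one that clears the scatter. The same exchange, read from the differently arranged ring of compound 1, gives a 2.4-fold lower number from compound 1 to compound 3 (0.37 log units; beyond the scatter), so the two compounds whose numbers could not be told apart both lie above compound 3, and the number on this ring responds to the loss of a methoxy group in a way it did not respond to the rearrangement of methoxy groups seen earlier. Nothing given here explains why this exchange lowers the number.

The compounds shown leave open whether this gain is specific to the position in question or would also follow from removing either of the two methoxy groups that remain in compound 3. They also leave open how a small substituent other than hydrogen at this place, such as a hydroxyl group, a fluorine atom or an amine, would compare with compound 3.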